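Swapping an Aryl Group for an Amine Chain: Cytotoxicity Outlook

The source may hold more compounds than are shown below. What is called first, only, known or untested is meant among the compounds shown, and "the series" means these compounds.

Three compounds sharing one core were tested in an ADME assay on MDBK cells (Bos taurus) for cytotoxicity; a lower number here means that less compound is tolerated, a higher number that more compound is tolerated. Compound 1 `Fc1cccc(F)c1Cn1c(-c2c(F)cccc2F)nc2ccncc21` gives 99000 nM. Compound 2 `COc1ccc(Cn2ccc3nc(-c4ccccc4)nc-3c2)cc1` reaches only the upper limit of this assay, reported as > 100000 nM. Compound 3 `CC(c1ccccc1)n1ccc2nc(-c3ccccc3)nc-2c1` likewise reaches only a limit, > 100000 nM. On these data alone, compound 2 therefore sits at the limit of > 100000 nM in this assay, at which 2 of the 3 values shown sit, so its true value is unknown and only known to lie beyond that point.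

The next compound, compound 4 `CC(C)N(CCn1ccc2nc(-c3ccccc3)nc-2c1)C(C)C`, differs from compound 2 by (diisopropylamino)methyl in place of 4-methoxyphenyl on a saturated chain carbon bound to an aromatic nitrogen. For the measured compounds named here, with no measured step of this kind available, the expected change from compound 2 to compound 4 is an at least 1.6-fold lower number from compound 2 to compound 4 (0.22 log units; that floor lies within the scatter), a modest drop that may stay within scatter. Compound 4 is estimated at 60000 nM, within the range 15000 nM to 150000 nM.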

Compound 4, half-maximal cytotoxic concentration: > 100000 nM
Compound 4: no number, only a limit; the forecaster's own chance of this, stated with the estimate: 40%; middle value at least 1.6-fold (0.22 log units) from the limit.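

No step can be read from compound 2 to compound 4, because both stop at the same limit: the limit of > 100000 nM in this assay, at which 3 of the 4 values shown sit. The compounds shown leave open how far (diisopropylamino)methyl in place of 4-methoxyphenyl changes the tolerated concentration, if at all.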